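A few compounds are considered here, and "the series" means these few. Any claim that something is new, unique, unknown or untested is made for them only; others in the source may bear on it.

Compound 1 `C=CCOc1ccc2c(=O)c(-c3cc(OC)c(OC)cc3OC)coc2c1` gives 5100 nM in a functional assay on B16 cells (Mus musculus) for antiproliferative activity, read by MTT assay, with a stated time of 24 h; a lower number here means a stronger inhibitor, a higher number a weaker inhibitor.
Compound 2 `COc1ccc2c(=O)c(-c3cc(OC)c(OC)cc3OC)coc2c1` gives 5200 nM in this assay.
Compound 3 `COc1cc(OC)c(-c2coc3cc(OCc4ccc(F)cc4)ccc3c2=O)cc1OC` gives 1120 nM in this assay.

Among these three numbers, compound 1 stands second highest. Its nearest neighbour is compound 2, with a 1.0-fold higher number from compound 1 to compound 2 (0.01 log units; within the scatter), so the two cannot be told apart. Its furthest neighbour is compound 3, with a 4.6-fold lower number from compound 1 to compound 3 (0.66 log units; beyond the scatter); the matching step a 4.6-fold lower number from compound 2 to compound 3 (0.67 log units; beyond the scatter) is of the same size, so replacing the small group at this position with a fluorinated aromatic ring brought a modest gain in both cases.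

Compound 4 `COc1cc(OC)c(-c2coc3cc(OCc4cccc(F)c4)ccc3c2=O)cc1OC` has not yet been measured. It differs from compound 1 in one place: 3-fluorophenyl in place of vinyl on a saturated chain carbon bound to an oxygen on an aromatic ring. For the measured compounds named here, the entering group is close to the one in compound 3, with the fluorine moved within the ring, and the measured steps toward compound 3 are the ones that bear on it. In this assay compound 4 is therefore expected to show a 3.9-fold lower number from compound 1 to compound 4 (0.59 log units; beyond the scatter), a modest step toward a lower number. The estimate for compound 4 is 1300 nM, with a range from 500 nM to 3500 nM.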

Compound 4, half-maximal inhibitory concentration: 2440 nM
Compound 4: middle estimate off by 1.9-fold (0.27 log units), on the low side; measured number inside the range.
By their numbers in this assay, from the lowest: compound 3; then compound 4; then compounds 1 and 2 (each within the scatter of the next).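

In this assay, 3-fluorophenyl in place of 4-fluorophenyl gives a 2.2-fold higher number from compound 3 to compound 4 (0.34 log units; beyond the scatter) and so shows that the place of the fluorine on the ring counts, not only the presence of a fluorinated ring. The 3-fluorophenyl group still beats both smaller groups, with a 2.1-fold lower number from compound 1 to compound 4 (0.32 log units; beyond the scatter) and a 2.1-fold lower number from compound 2 to compound 4 (0.33 log units; beyond the scatter) as its steps, but these gains are smaller than those seen with 4-fluorophenyl. Nothing measured here bears on why moving the fluorine shifts the number.

The compounds shown leave open how a plain phenyl ring with no fluorine, or a 4-chlorophenyl ring, would compare on the same saturated chain carbon. Also open, as far as these compounds go, is whether a longer chain ending in an amine or a carboxylic acid, with no aromatic ring, would keep any of the gain.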